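A fluoro swap near the limit of the assay

The compounds below may be only part of what the source reports. "The series", "measured", "known", "first", "only" and "open" are said of these compounds alone.

Compound 1 (`COc1ccc(/C=C2/c3cc(OC)cc(OC)c3[C@@H](c3ccc(OC)cc3)[C@@H]2c2cc(OC)cc(OC)c2)cc1`) is the only one of the three measured compounds with a true number: in a functional assay on RAW264.7 cells (Mus musculus) for inhibition, with stated times of 2 h and 24 h (a lower number here means a stronger inhibitor, a higher number a weaker inhibitor), compound 1 gives 6260 nM. Compound 2 (`COc1ccc([C@@H]2c3c(OC)cc(OC)cc3/C(=C/c3ccccc3)[C@H]2c2cc(OC)cc(OC)c2)cc1`) reports only a limit, > 200000 nM. Compound 3 (`COc1ccc([C@@H]2c3c(OC)cc(OC)cc3/C(=C/c3ccc(C)cc3)[C@H]2c2cc(OC)cc(OC)c2)cc1`) likewise reports only a limit, > 200000 nM. Compound 3 therefore stands at the limit of > 200000 nM in this assay, at which 2 of the 3 values shown sit.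

Compound 4 (`COc1ccc([C@@H]2c3c(OC)cc(OC)cc3/C(=C/c3ccc(F)cc3)[C@H]2c2cc(OC)cc(OC)c2)cc1`) has fluoro in place of methyl on an aromatic carbon, para to a large group: fluoro in place of methyl on an aromatic carbon. Two measured steps show what losing the methoxy did, both large: hydrogen in its place gave an at least 31-fold higher number from compound 1 to compound 2 (1.50 log units; beyond the scatter), and methyl in its place gave an at least 31-fold higher number from compound 1 to compound 3 (1.50 log units; beyond the scatter). The step closest to the new change, methyl in place of hydrogen, is a step that the two limits leave unreadable from compound 2 to compound 3, so it gives no size to carry over.

Compound 4 lacks the methoxy as well, so in this assay it is expected to stay close to the limit, with no step beyond the scatter in either direction, given an at least 31-fold higher number from compound 1 to compound 3 (1.50 log units; beyond the scatter). The expected result is a number no higher from compound 3 to compound 4 (the limit leaves the size open). For compound 4 the estimated value is 200000 nM, with an expected range from 60000 nM to 400000 nM.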

Compound 4, half-maximal inhibitory concentration: > 200000 nM
Compound 4: only a limit was reported (the forecaster's own chance of this, stated with the estimate: 70%); the middle value lies on the limit itself.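

With fluoro in place of methoxy on the same aromatic carbon, the result is an at least 31-fold higher number from compound 1 to compound 4 (1.50 log units; beyond the scatter). Hydrogen, methyl and fluoro have now all been tried at this position, and each replacement of the methoxy ends at the same reported ceiling in this assay: the limit of > 200000 nM in this assay, at which 3 of the 4 values shown sit.

The steps among compound 2, compound 3 and compound 4 have limits at both ends and cannot be read, so the shown compounds give no order among these three replacements.

As far as these compounds go, what remains open is whether a hydroxyl, an ethoxy or an amine at this position would bring the number back toward that of compound 1, which would show whether the methoxy itself is needed or could be exchanged for a related group. Also open, from the compounds shown here alone, is how far compound 2, compound 3 and compound 4 actually differ from one another, since their shared limit hides any difference.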